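The source may hold more compounds than are shown below. What is called first, only, known or untested is meant among the compounds shown, and "the series" means these compounds.

Measured so far:
compound 1, `CC[C@H](C)[C@H](NC(=O)c1cccc(Cn2ccnc2)c1)C(=O)NNS(=O)(=O)c1ccc(C)cc1`, 4%
compound 2, `CC[C@H](C)[C@H](NC(=O)c1cccc(Cn2ccnc2)c1)C(N)=O`, "not active" (no number reported)

In an assay on HEK293 cells for displacement of a labelled ligand from Type-2 angiotensin II receptor (Homo sapiens), tested at 1 uM (a higher number here means a stronger effect of the compound at the concentration tested, a lower number a weaker effect), compound 1 gives 4%. Compound 2 is reported in this assay as "not active" (no number reported), with no number behind it, so compound 2 stands only as inactive at the concentration tested, with no figure to set against compound 1. Compound 3, `CC[C@H](C)[C@H](NC(=O)c1cccc(Cn2ccnc2)c1)C(=O)NS(=O)(=O)c1ccccc1`, differs from compound 2 by phenylsulfonyl in place of hydrogen on an amide-type nitrogen. For the measured compounds named here, no measured pair shows this change, so the size of the step in this assay is open; with compound 1, which likewise carries a sulfonyl group, at 4%, nothing points to a rise beyond the scatter. Compound 3 is expected at 6%, range 0% to 20%.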

Compound 3, a percentage reported as inhibition, at one concentration (the size of the read-out at that concentration, not a potency): 5%
Compound 3: middle estimate off by 1 percentage points, on the high side; the range from low to high includes it.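

Swapping ((4-methylphenyl)sulfonyl)amino for phenylsulfonyl on the amide-type nitrogen gives a number 1 percentage points higher from compound 1 to compound 3 (within the scatter) in this assay and so does not separate the two sulfonyl-bearing groups at this position. The step from compound 2 to compound 3 cannot be read, as compound 2 has no number. No evidence on hand bears on this result. Compound 3 gives 5%. Open, as far as these compounds go, is whether a carboxylic acid or an amine at this position, in place of the sulfonyl-bearing groups, gives a read-out that differs from that of compound 3 by more than the scatter.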